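Series notes: step from compound 3 to compound 4

A few compounds are considered here, and "the series" means these few. Any claim that something is new, unique, unknown or untested is made for them only; others in the source may bear on it.

Three compounds carry numbers in an assay on COS-7 cells for inhibition of patatin-like phospholipase domain-containing protein 2 (Mus musculus), tested at 200 uM; on this read-out lower numbers stand for less inhibition and higher numbers for more inhibition at the one concentration tested (going by the name of the read-out). Compound 1 `CCOC(=O)c1cc(-c2ccc(OCC)cc2)ccn1` gives 72% in this assay. Compound 2 `CCOC(=O)c1cccc(-c2ccc(C)cc2)c1` gives 63%. Compound 3 `CCOc1ccc(-c2ccccc2)cc1` gives 35%, the lowest of the three numbers; its nearest neighbour is compound 2, whose number sits higher by more than the usual scatter, and compound 1 stands further off still, again beyond the scatter. Among the compounds with values here, no two of the measured compounds differ in a single place, so the set holds no measured step that could serve as a direct template.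

Compound 4 `CCOc1ccc(-c2cccc(C(=O)NC)c2)cc1` has not been measured. Against compound 3 the change is methylcarbamoyl in place of hydrogen on an aromatic carbon. The bare compound 3 sits at the bottom of the set, while compound 2 at 63% and compound 1 at 72% both lie well above it. On that footing a step upward from compound 3 is expected, of the size a number 20 percentage points higher from compound 3 to compound 4 (beyond the scatter), beyond the scatter in direction though with a broad uncertainty, since the change adds a group the measured set does not contain. Compound 4 is expected to give about 55% in this assay, within a range from 35% to 75%.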

Compound 4, a percentage reported as inhibition, at one concentration (the size of the read-out at that concentration, not a potency): 40%
For compound 4 the middle estimate is 15 percentage points above the measured one, within the range that was stated.
By their numbers in this assay, from the lowest: compounds 3 and 4 (each within the scatter of the next); then compounds 2 and 1 (each within the scatter of the next).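

Within the data shown here, this is the first step that can be read in a single place: in this assay, methylcarbamoyl in place of hydrogen on an aromatic carbon, meta to a group of 9 heavy atoms, gives a number 5 percentage points higher from compound 3 to compound 4 (within the scatter). At this place, then, the methylcarbamoyl group leaves the read-out indistinguishable from that of the unsubstituted ring, so adding this group here does not by itself separate the two compounds in this assay at the one concentration tested. Nothing measured on the series accounts for this result, and it offers no reason for the absence of a separable change.

Still open, on these data alone, is whether a carboxylic acid or an aminomethyl group on the same aromatic carbon, or a longer chain in place of the methyl of the methylcarbamoyl, would move the number beyond the scatter from compound 3. Also open, as far as these compounds go, is whether methylcarbamoyl at another place on that ring would give a step of similar size, as a single step at a single place defines no trend.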